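The source may hold more compounds than are shown below. What is called first, only, known or untested is meant among the compounds shown, and "the series" means these compounds.

Measured in an ADME assay on MDBK cells (Bos taurus) for cytotoxicity; a higher number here means that more compound is tolerated, a lower number that less compound is tolerated:
- compound 1 `c1ccc(Cn2ccc3nc(-c4ccccc4)nc-3c2)cc1`: > 100000 nM (a limit)
- compound 2 `Clc1cccc(Cn2ccc3nc(-c4ccccc4)nc-3c2)c1`: > 100000 nM (a limit)
- compound 3 `Brc1cccc(Cn2ccc3nc(-c4ccccc4)nc-3c2)c1`: 85000 nM

Not yet measured: compound 4 `N#Cc1ccccc1Cn1ccc2nc(-c3ccccc3)nc-2c1`.

Within the data shown here, compound 3 gives the only actual number in the set, 85000 nM. Against it stands (the limit of > 100000 nM in this assay, at which 2 of the 3 values shown sit).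

The next change leads to compound 4: 2-cyanophenyl in place of 3-bromophenyl on a saturated chain carbon bound to an aromatic nitrogen. In words, this is 2-cyanophenyl in place of 3-bromophenyl on a saturated chain carbon bound to an aromatic nitrogen.

Among the measured compounds shown here, no measured step involves a nitrile, so the evidence is indirect. The nearest steps are an at least 1.1-fold lower number from compound 1 to compound 3 (0.07 log units; that floor lies within the scatter) and an at least 1.1-fold lower number from compound 2 to compound 3 (0.07 log units; that floor lies within the scatter). The third is a step that the two limits leave unreadable from compound 1 to compound 2. On these steps, no change beyond the scatter is expected in this assay, although the expectation is loose. The expected step is a 1.1-fold higher number from compound 3 to compound 4 (0.02 log units; within the scatter). A report of a limit alone would not be surprising. For compound 4 the estimated value is 90000 nM, with an expected range of 40000 nM to 160000 nM.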

Compound 4, half-maximal cytotoxic concentration: > 100000 nM
Compound 4 was reported as a limit; the forecaster's own chance of this, stated with the estimate: 55%; middle value at least 1.1-fold (0.04 log units) from the limit.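

In this assay, 2-cyanophenyl in place of 3-bromophenyl on a saturated chain carbon bound to an aromatic nitrogen gives an at least 1.1-fold higher number from compound 3 to compound 4 (0.07 log units; that floor lies within the scatter). The steps to compound 4 from compound 1 and from compound 2 join two limits and cannot be read. The new information is that a nitrile-bearing group at this place also gives only a limit, leaving compound 3 as the sole compound with an actual number: the limit of > 100000 nM in this assay, at which 3 of the 4 values shown sit.

On these data alone, the actual values of compound 1, compound 2 and compound 4 remain open, so no order among them can be given. Also open, as far as these compounds go, is how this assay responds to an amine or a carboxylic acid on the phenyl ring, or to a longer chain in place of the saturated chain carbon.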